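The source may hold more compounds than are shown below. What is called first, only, known or untested is meant among the compounds shown, and "the series" means these compounds.

For the measured compounds named here, in a physicochemical assay for solubility, measured as kinetic solubility (on this read-out lower numbers stand for lower solubility and higher numbers for higher solubility), compound 2 `CCC/N=C1\S/C(=C\c2ccc(O)c(C(F)(F)F)c2)C(=O)N1c1ccccc1C` gives 14000 nM, the lowest of the three numbers so far. Compound 1 `CCC/N=C1\S/C(=C\c2ccc(O)c(Cl)c2)C(=O)N1C1CCS(=O)(=O)CC1` gives 75000 nM and compound 3 `CCC/N=C1\S/C(=C\c2ccc(O)c(Cl)c2)C(=O)N1c1ccccc1O` gives 220000 nM.

The next compound is compound 4 `CCC/N=C1\S/C(=C\c2ccc(O)c(Br)c2)C(=O)N1c1ccccc1C`, which differs from compound 2 by bromo in place of trifluoromethyl on an aromatic carbon, the rest of the structure unchanged.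

Going by the values given here, no measured pair covers this exchange. Among the compounds with values here, the only measured step, a 2.9-fold higher number from compound 1 to compound 3 (0.47 log units; beyond the scatter), is a change on an amide-type nitrogen in a ring, so it bears on the exchange only indirectly and gives no size for it. Compound 1 and compound 3 both carry chloro on the corresponding aromatic carbon and both stand higher than compound 2, but they also differ from compound 2 in the group on that nitrogen. The two changes cannot be separated with these data, so they offer only a weak lean towards a higher number.

In this assay, no change beyond the scatter is therefore expected, and the estimated step is a 1.4-fold higher number from compound 2 to compound 4 (0.13 log units; within the scatter). For compound 4 the estimated value is 19000 nM, with an expected range of 7000 nM to 50000 nM.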

Compound 4, solubility: 79000 nM
Beside the measured number, compound 4's estimate is 4.2-fold (0.62 log units) below it; measured number outside the range, above it.
By their numbers in this assay, from the lowest: compound 2; then compounds 1 and 4 (each within the scatter of the next); then compound 3.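

In this assay, for the compounds shown here, bromo in place of trifluoromethyl on the aromatic carbon ortho to a hydroxy group gives a 5.6-fold higher number from compound 2 to compound 4 (0.75 log units; beyond the scatter) with the rest of the structure unchanged, which makes this the first clean reading at this position. Going by these compounds alone, the earlier compounds offered only one clean step, at the amide-type nitrogen in a ring, a 2.9-fold higher number from compound 1 to compound 3 (0.47 log units; beyond the scatter), so any contribution from the aromatic carbon could not be separated from a change at that nitrogen; the new pair shows that this position alone can move the read-out beyond the scatter. No measurement shown here accounts for the size or direction of the step.

As far as these compounds go, it remains open whether a step of this size carries over when the group on the amide-type nitrogen is a different one, such as the 1,1-dioxothian-4-yl of compound 1 or the 2-hydroxyphenyl of compound 3. Also open, from the compounds shown here alone, is how a nitrile, a methoxy group or a primary amine on this same aromatic carbon would stand against bromo and trifluoromethyl on the shared core.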